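Adding a fluoro group to the chlorophenyl amide

The source may hold more compounds than are shown below. What is called first, only, known or untested is meant among the compounds shown, and "the series" means these compounds.

Measured compounds:
compound 1 `O=C(CSc1nc(Nc2ccccc2)c2ccccc2n1)Nc1ccccc1F`, 12400 nM
compound 2 `O=C(CSc1nc(Nc2ccccc2)c2ccccc2n1)Nc1cccc(Cl)c1`, 12600 nM

In a functional assay on PC-3 cells (Homo sapiens) for inhibition, read by MTT assay, with a stated time of 72 h (a lower number here means a stronger inhibitor, a higher number a weaker inhibitor), compound 2 gives 12600 nM, and compound 1 gives 12400 nM; the two numbers lie within the scatter of each other, so compound 2 stands level with compound 1. Compound 3 `O=C(CSc1nc(Nc2ccccc2)c2ccccc2n1)Nc1ccc(F)c(Cl)c1` differs from compound 2 by fluoro in place of hydrogen on an aromatic carbon. For the measured compounds named here, the one step measured on this amide-type aryl group, a 1.0-fold higher number from compound 1 to compound 2 (0.01 log units; within the scatter), changed the number hardly at all. On that basis the step from compound 2 to compound 3 is expected to stay within the scatter, no change at the digits printed from compound 2 to compound 3 (within the scatter). Compound 3 is therefore estimated at 12600 nM, with a range from 6000 nM to 26000 nM in this assay.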

Compound 3, half-maximal inhibitory concentration: 15500 nM
Compound 3: middle estimate off by 1.2-fold (0.09 log units), on the low side; the measured number falls inside the stated range.
By their numbers in this assay, from the lowest: compounds 1, 2 and 3 (each within the scatter of the next).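

In this assay a fluoro group is tolerated on the aromatic carbon ortho to the chloro group and para to a large group (a 1.2-fold higher number from compound 2 to compound 3 (0.09 log units; within the scatter)), a position that carries hydrogen in compound 2. The 3-chloro-4-fluorophenyl group also stands level with the 2-fluorophenyl group (a 1.3-fold higher number from compound 1 to compound 3 (0.10 log units; within the scatter)). No evidence bears on the result.

The compounds shown leave open whether an amine or a carboxylic acid at this position would move the number beyond the scatter. They also leave open whether any change outside the amide-type aryl group would do so.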